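A Larger Group Enters the Aryl Amide

A few compounds are considered here, and "the series" means these few. Any claim that something is new, unique, unknown or untested is made for them only; others in the source may bear on it.

Three analogues share one core and differ only in the aryl amide. In a functional assay on MGC-803 cells (Homo sapiens) for cytotoxicity, read by MTT assay, with a stated time of 72 h (on this read-out higher numbers stand for weaker inhibition and lower numbers for stronger inhibition), compound 1 `O=C(CSC(=S)N[C@H]1CCOC1=O)Nc1ccccc1F` gives 122000 nM, compound 2 `O=C(CSC(=S)N[C@H]1CCOC1=O)Nc1ccccc1Cl` gives 32000 nM, and compound 3 `Cc1ccc(NC(=O)CSC(=S)N[C@H]2CCOC2=O)cc1` gives 44300 nM. Compound 3 therefore holds the second highest of the three numbers: the nearest number lies within the scatter, a 1.4-fold higher number from compound 2 to compound 3 (0.14 log units; within the scatter), while the furthest lies beyond it, a 2.8-fold lower number from compound 1 to compound 3 (0.44 log units; beyond the scatter). Compound 4 `O=C(CSC(=S)N[C@H]1CCOC1=O)Nc1ccc(C(=O)/C=C/c2ccccc2)cc1` alters compound 3 by (2-phenylethenyl)carbonyl in place of methyl on an aromatic carbon. Every measured step swaps one small substituent for another, so none bears directly on adding a group of this size; the largest of them, a 3.8-fold lower number from compound 1 to compound 2 (0.58 log units; beyond the scatter), was only modest. A modest further lowering is expected, a 3.0-fold lower number from compound 3 to compound 4 (0.47 log units; beyond the scatter). Compound 4 is estimated at 15000 nM, with a range from 3000 nM to 60000 nM.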

Compound 4, half-maximal inhibitory concentration: 24800 nM
For compound 4 the middle estimate is 1.7-fold (0.22 log units) below the measured one; the range from low to high includes it.
By their numbers in this assay, from the lowest: compounds 4, 2 and 3 (each within the scatter of the next); then compound 1.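

On the aromatic carbon that carries methyl in compound 3, (2-phenylethenyl)carbonyl brings a 1.8-fold lower number from compound 3 to compound 4 (0.25 log units; within the scatter) in this assay. The earlier steps shown here only exchanged small substituents, whereas this one shows that a far larger group with its own aromatic ring can stand here without moving the number beyond the scatter. No measurement available here explains this result. Still open, going by these compounds, is whether the carbonyl, the double bond or the added ring matters here, which a plain benzoyl group could help separate. An amine or a carboxylic acid at this place also remains untested among the compounds shown.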